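Bromo Analogue of a Hydroxyphenyl Pyridyl Ketone

The source may hold more compounds than are shown below. What is called first, only, known or untested is meant among the compounds shown, and "the series" means these compounds.

Measured so far:
Compound 1 `O=C(c1cccnc1)c1ccccc1O`: 33400 nM
Compound 2 `O=C(c1cccnc1)c1cccc(Cl)c1O`: 31500 nM

In a functional assay on PC-3 cells (Homo sapiens) for cytotoxicity, read by sulforhodamine B assay, with a stated time of 48 h (on this read-out higher numbers stand for weaker inhibition and lower numbers for stronger inhibition), compound 1 gives 33400 nM, the highest of the two numbers. Its nearest neighbour is compound 2, which gives 31500 nM. For the measured compounds named here, the only step seen so far, a 1.1-fold lower number from compound 1 to compound 2 (0.03 log units; within the scatter), shows that adding a halogen to the hydroxy-bearing ring left the read-out essentially unchanged. Compound 3 `O=C(c1cccnc1)c1cc(Br)ccc1O` differs from compound 1 by bromo in place of hydrogen on an aromatic carbon. Going by the values given here, with only that one halogen step as guidance, no step beyond the scatter is expected in this assay. Compound 3 is therefore estimated at 30000 nM, within 15000 nM to 60000 nM, which means an expected 1.1-fold lower number from compound 1 to compound 3 (0.05 log units; within the scatter).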

Compound 3, half-maximal inhibitory concentration: 60200 nM
The estimate for compound 3 lay 2.0-fold (0.30 log units) below the measured number, and the stated range ends below it.
By their numbers in this assay, from the lowest: compounds 2, 1 and 3 (each within the scatter of the next).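

Bromo para to the hydroxy group gives a 1.8-fold higher number from compound 1 to compound 3 (0.26 log units; within the scatter) in this assay. This aromatic carbon therefore takes a bromine atom in place of hydrogen without a shift beyond the scatter, although the step comes close to that limit. No measurement shown gives a reason for this step. As far as these compounds go, it remains open whether an amine or a carboxylic acid on this same carbon would move the number beyond the scatter. A longer chain there is equally untested by the compounds shown, so the tolerance seen for bromo cannot be extended to larger or different groups.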